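Methoxy in place of chloro on compound 1

The source may report more compounds than this note shows. Statements on the series, on what has been measured and on what is new or still open speak of the compounds shown alone.

Among the measured compounds shown here, compound 1 `Oc1ccccc1/C=N/c1nnc(SCc2nnc(-c3ccc(Cl)cc3)o2)s1` stands with the highest number of the three measured so far in a functional assay on A549 cells (Homo sapiens) for inhibition, read by CCK-8 assay (a higher number here means a weaker inhibitor, a lower number a stronger inhibitor), giving 30100 nM. Its nearest neighbour is compound 3 `Cc1ccc(-c2nnc(CSc3nnc(/N=C/c4ccccc4O)s3)o2)cc1`, which gives 22000 nM; the step of a 1.4-fold lower number from compound 1 to compound 3 (0.14 log units; within the scatter) lies within the scatter, so the two cannot be ordered. Compound 2 `Cc1ccccc1-c1nnc(CSc2nnc(/N=C/c3ccccc3O)s2)o1` gives 7850 nM, and the step of a 3.8-fold lower number from compound 1 to compound 2 (0.58 log units; beyond the scatter) is the only one that clearly separates a member of the series from compound 1. Between the two methyl isomers the step of a 2.8-fold higher number from compound 2 to compound 3 (0.45 log units; beyond the scatter) is also beyond the scatter.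

Compound 4 `COc1ccc(-c2nnc(CSc3nnc(/N=C/c4ccccc4O)s3)o2)cc1` has not been measured. Relative to compound 1 the change is methoxy in place of chloro on an aromatic carbon. The step that bears on it most directly is a 1.4-fold lower number from compound 1 to compound 3 (0.14 log units; within the scatter), where a different small group took the same place and the step stayed within the scatter. For the measured compounds named here, no other pair among the measured compounds shares that place, so the one step is the whole of the precedent. The change from compound 1 to compound 4 is therefore expected to stay within the scatter, as a 1.4-fold lower number from compound 1 to compound 4 (0.14 log units; within the scatter). Compound 4 is expected to give about 22000 nM in this assay, with a range from 8000 nM to 60000 nM.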

Compound 4, half-maximal inhibitory concentration: 20300 nM
Beside the measured number, compound 4's estimate is 1.1-fold (0.03 log units) above it, within the range that was stated.
By their numbers in this assay, from the lowest: compound 2; then compounds 4, 3 and 1 (each within the scatter of the next).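

On the aromatic carbon para to a large group, 4-chlorophenyl to 4-methoxyphenyl gives a 1.5-fold lower number from compound 1 to compound 4 (0.17 log units; within the scatter) in this assay, and replacing methyl with methoxy gives a 1.1-fold lower number from compound 3 to compound 4 (0.03 log units; within the scatter) as well, so a second substituent now stays within the scatter here, and compound 1, compound 3 and compound 4 cannot be ordered, even though methoxy brings one more heavy atom and a hydrogen-bond acceptor that chloro lacks. The separation of compound 2 also holds against a second group at this place, with a 2.6-fold higher number from compound 2 to compound 4 (0.41 log units; beyond the scatter) as the step, so among the four compounds, only compound 2, with its 2-methylphenyl group, stands apart from the others. Nothing on hand gives a measured reason for either the flat response or the separate standing of compound 2.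

Methyl, chloro and methoxy are the only groups seen at this carbon, so it remains open whether an amine, a carboxylic acid or a longer chain such as butoxy would shift the number beyond the scatter. On these data alone, the lower number of compound 2 rests on a single compound, and whether a group other than methyl in the same place would repeat it also remains open.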